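Imidazolyl to pyridyl on the oxime carbamate side chain

The compounds below may be only part of what the source reports. "The series", "measured", "known", "first", "only" and "open" are said of these compounds alone.

Three measured compounds share a carbamate core. Within the data shown here, compound 1 `O=C(Nc1ccccc1)O/N=C(\C1CCCCC1)C(CN1CCN(c2ccccc2)CC1)C1CCCCC1` is the first. In an assay on isolated protein for displacement of a labelled ligand from metabotropic glutamate receptor 5 (Rattus norvegicus) (a lower number here means a stronger inhibitor, a higher number a weaker inhibitor), compound 1 gives only a limit, > 1000 nM, not a number. Compound 2 `O=C(Nc1ccccc1)O/N=C(\C1CCCCC1)C(CN1CCc2ccccc2C1)C1CCCCC1` in this assay likewise gives a limit, > 1000 nM. The step that the two limits leave unreadable from compound 1 to compound 2 cannot be read. Compound 3 `Cc1nccn1CC(/C(=N/OC(=O)Nc1cccc(Cl)c1)C1CCCCC1)C1CCCCC1` in this assay also gives a limit, > 1000 nM. Compound 3 therefore stands where compounds 1 and 2 stand, because of the limit of > 1000 nM in this assay, at which 3 of the 3 values shown sit, with no number separating the three.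

Compound 4 `O=C(Nc1cccc(Cl)c1)O/N=C(\C1CCCCC1)C(Cc1ccccn1)C1CCCCC1` differs from compound 3 by pyridin-2-yl in place of 2-methyl-1H-imidazol-1-yl on a saturated chain carbon, two bonds along the chain from a carbon with a double bond to nitrogen and a saturated ring carbon. Among the measured compounds shown here, no measured step touches this change; the only step available, a step that the two limits leave unreadable from compound 1 to compound 2, concerns another part of the chain and is itself unreadable between two limits. Nothing in the numbers supports expecting a step beyond the scatter in either direction. The estimated step that the limit leaves unreadable from compound 3 to compound 4 is therefore set close to nothing. Compound 4 is expected to give 3000 nM in this assay, within a range from 700 nM to 20000 nM, and is most likely to be reported again as a limit.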

Compound 4, inhibition constant: 40.4 nM
Compound 4: middle estimate off by 74-fold (1.87 log units), on the high side; the measured number lies below the stated range.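

In this assay, among these compounds, pyridin-2-yl in place of 2-methyl-1H-imidazol-1-yl on the saturated chain carbon gives an at least 24-fold lower number from compound 3 to compound 4 (1.39 log units; beyond the scatter), the first step that can be read, so the group at this place can decide the result. The step has no fixed far end because compound 3 gives only a limit: the limit of > 1000 nM in this assay, at which 3 of the 4 values shown sit. The two compounds differ in this one place only, so the shared core does not by itself hold a compound at the limit.

The compounds shown do not tell whether the gain depends on the ring nitrogen of pyridin-2-yl, which phenyl, pyridin-3-yl or pyridin-4-yl at the same place would test. They also leave open whether imidazol-1-yl without its methyl group would stay at the limit.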